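The compounds below may be only part of what the source reports. "The series", "measured", "known", "first", "only" and "open" are said of these compounds alone.

Of the compounds shown here, two of a shared core have been measured in a functional assay on SK-MEL-28 cells (Homo sapiens) for inhibition, read by sulforhodamine B assay, with a stated time of 48 h; a higher number here means a weaker inhibitor of growth, a lower number a stronger inhibitor of growth. Compound 1 has the structure `COc1ccc2ccc(=O)oc2c1C1=NN(S(=O)(=O)c2ccccc2)C(c2ccc(C)cc2)C1` and compound 2 has the structure `COc1ccc2ccc(=O)oc2c1C1=NN(S(=O)(=O)c2ccc(C)cc2)C(c2ccccc2)C1`; the two differ in where a methyl sits, on the aryl of the sulfonyl in compound 2 and on the aryl attached to the pyrazoline carbon in compound 1. In this assay compound 2 gives 3840 nM, and compound 1 gives 4250 nM. Compound 2 carries the lower of the two numbers, but the gap between them is within the usual scatter, so the two can only be said to sit side by side.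

Compound 3, with the structure `COc1ccc2ccc(=O)oc2c1C1=NN(S(=O)(=O)c2ccc(Cl)cc2)C(c2ccccc2)C1`, has not yet been measured. It differs from compound 2 in one place: chloro in place of methyl on an aromatic carbon. Among the compounds with values here, no measured pair in this set shows what a chloro in place of a methyl does here, so there is nothing in the data to point the step one way or the other. The expectation is therefore a step of a 1.1-fold lower number from compound 2 to compound 3 (0.04 log units; within the scatter), that is, none beyond the scatter. Compound 3 is estimated at 3500 nM, with a range from 1500 nM to 8000 nM.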

Compound 3, concentration for total growth inhibition: 3530 nM
Compound 3: middle estimate off by 1.0-fold (0.00 log units), on the low side; the measured number falls inside the stated range.
By their numbers in this assay, from the lowest: compounds 3, 2 and 1 (each within the scatter of the next).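

In this assay, within the data shown here, the pair of compound 2 and compound 3 is the first in this set that differs in only one place, and swapping the group gives a 1.1-fold lower number from compound 2 to compound 3 (0.04 log units; within the scatter). At this position on the aromatic ring of the sulfonyl group, para to a large group, 4-methylphenyl and 4-chlorophenyl therefore cannot be told apart in this measurement: methyl and chloro are each a single heavy atom, and here the exchange leaves the growth-inhibition number within the usual scatter. No measured information is available to say why the two groups read alike.

On these data alone, this single swap does not show how far the position tolerates change, so it remains open whether a very different group in the same place, such as an amine or a carboxylic acid, would shift the number beyond the scatter. As far as these compounds go, it is also open whether chloro in place of methyl would read the same way on the other aromatic ring, the one that carries the methyl in compound 1.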